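Acetyl to benzyl on the shared core: working notes

The source may report more compounds than this note shows. Statements on the series, on what has been measured and on what is new or still open speak of the compounds shown alone.

Values in a functional assay on HOS cells (Homo sapiens) for antiproliferative activity, read by sulforhodamine B assay; on this read-out lower numbers stand for stronger inhibition of growth and higher numbers for weaker inhibition of growth:
- compound 1 `CC[C@@H]1O[C@H](COCc2ccccc2)[C@@H](OCc2ccccc2)[C@H](OCc2ccccc2)[C@H]1O`: 34200 nM
- compound 2 `CC(=O)OC[C@H]1O[C@@H](Cc2ccccc2)[C@H](OC(C)=O)[C@@H](OCc2ccccc2)[C@@H]1OC(C)=O`: > 50000 nM, a limit and not a number

Compound 2 has no number in this assay, only a limit: the limit of > 50000 nM in this assay, at which 1 of the 2 values shown sits. Its true position is therefore unknown, and any step starting from it is loosely defined.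

Compound 3 `CC(=O)O[C@@H]1[C@@H](OCc2ccccc2)[C@H](OC(C)=O)[C@@H](COCc2ccccc2)O[C@H]1Cc1ccccc1` differs from compound 2 by benzyl in place of acetyl on an oxygen on a saturated carbon, the acetoxymethyl becoming (benzyloxy)methyl: benzyl in place of acetyl on an oxygen on a saturated carbon.

For the measured compounds named here, no measured step covers this change, so the expectation rests on little. Going by the values given here, the only true number is that of compound 1, at 34200 nM, and this suggests that weak growth inhibition is the likely range. In this assay, a small expected move toward stronger inhibition of growth is the best guess, with no change beyond the scatter also quite possible. The expected size is an at least 1.2-fold lower number from compound 2 to compound 3 (0.09 log units; that floor lies within the scatter). A further limit reading would not be surprising. Compound 3 is estimated at 40000 nM, with an expected range of 15000 nM to 90000 nM.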

Compound 3, concentration for 50% growth inhibition: 6100 nM
Compound 3: the middle estimate sits 6.6-fold (0.82 log units) above what was measured; measured number below the stated range.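

In this assay, benzyl in place of acetyl on an oxygen on a saturated carbon, with acetoxymethyl becoming (benzyloxy)methyl, gives an at least 8.1-fold lower number from compound 2 to compound 3 (0.91 log units; beyond the scatter). Compound 2 has a limit and not a number, so this size is only a floor and the true step may be larger: the limit of > 50000 nM in this assay, at which 1 of the 3 values shown sits. The direction at this place on the shared core is now fixed, with (benzyloxy)methyl giving stronger inhibition of growth than acetoxymethyl, which compound 1 could not show as it differs from both compounds in more than one place.

The pair does not separate the effect of the entering benzyl from that of the leaving acetyl, and a free hydroxyl, a methyl ether or a cyclohexylmethyl ether on this oxygen would tell these apart. As far as these compounds go, it also remains open whether the same exchange at the remaining acetoxy groups of compound 3 would give a step of similar direction and size.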